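Morpholine carbonyl replaces pyridine carbonyl on a proline amide

The source may report more compounds than this note shows. Statements on the series, on what has been measured and on what is new or still open speak of the compounds shown alone.

Compound 1 `CN(C)CC(=O)N1CCC[C@H]1C(=O)N1CCC(NS(=O)(=O)c2cc(S(=O)(=O)c3ccccc3)ccc2C(F)(F)F)CC1`, in a functional assay on U2OS cells for antagonist activity at proto-oncogene Wnt-3 (Homo sapiens), read by a luciferase reporter, with a stated time of 18 h (on this read-out higher numbers stand for an effect only at larger amounts of compound and lower numbers for an effect already at smaller amounts), compound 1 gives 310 nM.
Compound 2 `CN(C)c1ccc(C(=O)N2CCC[C@H]2C(=O)N2CCC(NS(=O)(=O)c3cc(S(=O)(=O)c4ccccc4)ccc3C(F)(F)F)CC2)cc1`, in this assay compound 2 gives 830 nM.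
Compound 3 `O=C([C@@H]1CCCN1C(=O)c1ccncc1)N1CCC(NS(=O)(=O)c2cc(S(=O)(=O)c3ccccc3)ccc2C(F)(F)F)CC1`, in this assay compound 3 gives 350 nM.

Compound 3 stands second highest of the three; its step to compound 1 is within the scatter (a 1.1-fold higher number from compound 1 to compound 3 (0.05 log units; within the scatter)), while a 2.4-fold lower number from compound 2 to compound 3 (0.38 log units; beyond the scatter) is modest. Compound 4 `O=C([C@@H]1CCCN1C(=O)N1CCOCC1)N1CCC(NS(=O)(=O)c2cc(S(=O)(=O)c3ccccc3)ccc2C(F)(F)F)CC1` carries morpholin-4-yl in place of pyridin-4-yl on a carbonyl carbon. Going by the values given here, no measured step involves a morpholin-4-yl group, so none bears directly on this change; the three measured compounds, differing only at this carbonyl carbon, span a 2.7-fold higher number from compound 1 to compound 2 (0.43 log units; beyond the scatter) at most. A step of similar or smaller size is therefore expected in this assay, in no firm direction. Compound 4 is estimated at 420 nM (range 180 nM to 1000 nM), an expected step of a 1.2-fold higher number from compound 3 to compound 4 (0.08 log units; within the scatter).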

Compound 4, half-maximal effective concentration: 280 nM
For compound 4 the middle estimate is 1.5-fold (0.18 log units) above the measured one, within the range that was stated.
By their numbers in this assay, from the lowest: compounds 4, 1 and 3 (each within the scatter of the next); then compound 2.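

In this assay, morpholin-4-yl on this carbonyl carbon gives a number within the scatter of pyridin-4-yl, with a 1.3-fold lower number from compound 3 to compound 4 (0.10 log units; within the scatter), and of (dimethylamino)methyl, with a 1.1-fold lower number from compound 1 to compound 4 (0.04 log units; within the scatter), so a non-aromatic ring fits here as well as these two groups. The 4-(dimethylamino)phenyl group of compound 2 remains the one that stands apart, with a 3.0-fold lower number from compound 2 to compound 4 (0.47 log units; beyond the scatter). Nothing available explains these numbers. Going by these compounds, whether a carboxylic acid, a piperazine or a longer chain on this carbonyl carbon would stay in the same range remains open.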